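From 4-chlorophenyl to 3-nitrophenyl: what to expect next

The compounds below may be only part of what the source reports. "The series", "measured", "known", "first", "only" and "open" are said of these compounds alone.

Compound 1 `CCCCCCCCCCCCCCNC(=O)[C@H](CO)/N=C/c1ccc(OC)cc1` gives 81700 nM in an ADME assay on HEK293 cells (Homo sapiens) for cytotoxicity; on this read-out higher numbers stand for weaker inhibition and lower numbers for stronger inhibition
Compound 2 `CCCCCCCCCCCCCCNC(=O)[C@H](CO)/N=C/c1ccccc1Cl` gives 94900 nM in this assay
Compound 3 `CCCCCCCCCCCCCCNC(=O)[C@H](CO)/N=C/c1ccc(Cl)cc1` gives 77700 nM in this assay

Compound 3 stands level with the other two compounds, since its gaps to both lie within the scatter of repeat measurements. The next compound, compound 4 `CCCCCCCCCCCCCCNC(=O)[C@H](CO)/N=C/c1cccc([N+](=O)[O-])c1`, differs from compound 3 in one group: 3-nitrophenyl in place of 4-chlorophenyl on a carbon with a double bond to nitrogen on a carbon with a double bond to nitrogen.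

The three measured steps all exchange a group at this same place. They are a 1.2-fold higher number from compound 1 to compound 2 (0.07 log units; within the scatter) and a 1.1-fold lower number from compound 1 to compound 3 (0.02 log units; within the scatter) and a 1.2-fold lower number from compound 2 to compound 3 (0.09 log units; within the scatter) and each is within the scatter. Changes here have so far left the number in place, but no compound with 3-nitrophenyl has been measured, so this new group remains untested.

The expected step is a 1.0-fold lower number from compound 3 to compound 4 (0.02 log units; within the scatter) and this estimate lies within the scatter. Compound 4 is expected at about 75000 nM with an estimated range from 40000 nM to 130000 nM in this assay.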

Compound 4, half-maximal inhibitory concentration: 82700 nM
Compound 4: the middle estimate sits 1.1-fold (0.04 log units) below what was measured; measured number inside the range.
By their numbers in this assay, from the lowest: compounds 3, 1, 4 and 2 (each within the scatter of the next).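

The 3-nitrophenyl group has more heavy atoms than 4-chlorophenyl and carries hydrogen-bond acceptors where 4-chlorophenyl has none, yet this assay shows only a 1.1-fold higher number from compound 3 to compound 4 (0.03 log units; within the scatter). Set against the other two groups at this place, it gives a 1.1-fold lower number from compound 2 to compound 4 (0.06 log units; within the scatter) and a 1.0-fold higher number from compound 1 to compound 4 (0.01 log units; within the scatter). A ring bearing a nitro group therefore joins the methoxy and chloro rings on the carbon with a double bond to nitrogen, and all four compounds stand level.

No measurement at hand bears on what lies behind this result. As far as these compounds go, it also remains open whether a ring carrying an amine or a carboxylic acid at this place would stay level too, or would move the number beyond the scatter.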